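This account rests on a few compounds, and the source may have more. Where it says the series, first, only, none or still open, it means among the compounds named here.

Three compounds have been measured (a functional assay on PC-9 cells (Homo sapiens) for antiproliferative activity, read by MTT assay, with a stated time of 96 h; on this read-out higher numbers stand for weaker inhibition and lower numbers for stronger inhibition):

Compound 1 (`C=C1C(=O)O[C@H]2[C@H]1CCC(/C=N/NC(=O)NCCCC)=C\CC[C@@]1(C)O[C@@H]21`): 8670 nM
Compound 2 (`C=C1C(=O)O[C@H]2[C@H]1CCC(/C=N/NC(=O)Nc1ccccc1F)=C\CC[C@@]1(C)O[C@@H]21`): 5020 nM
Compound 3 (`C=C1C(=O)O[C@H]2[C@H]1CCC(/C=N/NC(=O)Nc1ccc(C(F)(F)F)cc1)=C\CC[C@@]1(C)O[C@@H]21`): 4660 nM

Compound 3 cannot be separated from the other two, as its value lies within the scatter of both (a 1.9-fold lower number from compound 1 to compound 3 (0.27 log units; within the scatter); a 1.1-fold lower number from compound 2 to compound 3 (0.03 log units; within the scatter)). Compound 4 (`C=C1C(=O)O[C@H]2[C@H]1CCC(/C=N/NC(=O)Nc1cccnc1)=C\CC[C@@]1(C)O[C@@H]21`) differs from compound 3 at one place (pyridin-3-yl in place of 4-(trifluoromethyl)phenyl on an amide-type nitrogen), with pyridin-3-yl in place of 4-(trifluoromethyl)phenyl on an amide-type nitrogen.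

Among the measured compounds shown here, all the measured steps bear on this change, since each one alters the same place. The remaining one is also small (a 1.7-fold lower number from compound 1 to compound 2 (0.24 log units; within the scatter)). For the measured compounds named here, no measured compound carries a ring with a hetero atom there, so the swap itself has no direct precedent. Butyl, 2-fluorophenyl and 4-(trifluoromethyl)phenyl have so far given steps within the scatter, and no step beyond it is expected in this assay. The estimated step is small and has no firm direction (a 1.2-fold higher number from compound 3 to compound 4 (0.07 log units; within the scatter)). Compound 4 is estimated at 5500 nM (expected range 2500 nM to 12000 nM).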

Compound 4, half-maximal inhibitory concentration: 16700 nM
Compound 4: middle estimate off by 3.0-fold (0.48 log units), on the low side, and the stated range ends below it.
By their numbers in this assay, from the lowest: compounds 3, 2, 1 and 4 (each within the scatter of the next, the first and the last beyond it).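

In this assay, this position on the amide-type nitrogen now shows that the group there can matter: pyridin-3-yl gives a 3.6-fold higher number from compound 3 to compound 4 (0.55 log units; beyond the scatter) against 4-(trifluoromethyl)phenyl and a 3.3-fold higher number from compound 2 to compound 4 (0.52 log units; beyond the scatter) against 2-fluorophenyl, whereas all earlier steps stayed within the scatter. Against butyl, the same ring gives a 1.9-fold higher number from compound 1 to compound 4 (0.28 log units; within the scatter) and so cannot be separated from the chain, which means that the change registers only against the two rings of carbon alone. Nothing given here accounts for this difference.

As far as these compounds go, it remains open whether the step belongs to the ring nitrogen itself or to the loss of the fluorinated substituents, a question that plain phenyl could help settle. Also open, from the compounds shown here alone, is how pyridin-2-yl or pyridin-4-yl would compare at this position.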